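Pentyl ether step carried onto a second core

The source may hold more compounds than are shown below. What is called first, only, known or untested is meant among the compounds shown, and "the series" means these compounds.

Compound 1 `COc1ccc2cc(CCCO)oc(=O)c2c1` and its pentyl ether compound 2 `CCCCCOCCCc1cc2ccc(OC)cc2c(=O)o1` were both run in a functional assay on PC-3 cells (Homo sapiens) for antiproliferative activity, read by sulforhodamine B assay, with a stated time of 48 h; a lower number here means a stronger inhibitor of growth, a higher number a weaker inhibitor of growth; compound 1 gives 25.9 ug/mL and compound 2 gives 8 ug/mL. The change pentyl in place of hydrogen on an oxygen on a saturated carbon produced a 3.2-fold lower number from compound 1 to compound 2 (0.51 log units; beyond the scatter). Compound 3 `COc1ccc2c(c1)C(=O)OC(CCCO)C2` stands on a different core; the difference between the two cores is not broken down here. In this assay compound 3 gives 70.7 ug/mL, the highest of the three numbers. Compound 4 `CCCCCOCCCC1Cc2ccc(OC)cc2C(=O)O1` carries the same change on the core of compound 3, namely (pentyl in place of hydrogen on an oxygen on a saturated carbon), at the same place as before. Among the compounds with values here, on that basis the expected step is a 2.8-fold lower number from compound 3 to compound 4 (0.45 log units; beyond the scatter), resting on a 3.2-fold lower number from compound 1 to compound 2 (0.51 log units; beyond the scatter) as the only measured instance of this change. Compound 4 is accordingly estimated at 25 ug/mL, with a likely range from 10 ug/mL to 60 ug/mL.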

Compound 4, concentration for 50% growth inhibition: 29.5 ug/mL
For compound 4 the middle estimate is 1.2-fold (0.07 log units) below the measured one; low and high end bracket the measured number.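

In this assay the pentyl ether gives a 2.4-fold lower number from compound 3 to compound 4 (0.38 log units; beyond the scatter) on the second core, so the direction seen on the core of compound 1 holds here. The size of the step also carries over between the two cores: the same change on two cores in this assay, a 3.2-fold lower number (0.51 log units; beyond the scatter) from compound 1 to compound 2 and a 2.4-fold lower number (0.38 log units; beyond the scatter) from compound 3 to compound 4, 1.4-fold (0.13 log units) apart, within the scatter of two such steps. Within the data shown here, this rests on only two pairs, in one assay and with one ether chain, so it does not show that the step would hold on any further core or with any other group.

From the compounds shown here alone, whether a shorter or longer chain in place of pentyl would give a step of similar size on both cores remains open. Also open, going by these compounds, is how an amine or a carboxylic acid in that place would behave.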